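This account rests on a few compounds, and the source may have more. Where it says the series, first, only, none or still open, it means among the compounds named here.

Measured so far:

Compound 1 `COc1ccc(F)cc1Nc1cc(NC(=O)Nc2c(Cl)cccc2Cl)ncn1` — 31.3%
Compound 2 `COc1cc(NC(=O)Nc2cc(Nc3ccc(C)c(C)c3)ncn2)cc(OC)c1` — 45.3%

In a functional assay on NCI-H226 cells (Homo sapiens) for inhibition, read by MTT assay, with a stated time of 48 h, tested at 10 uM (a lower number here means less inhibition, a higher number more inhibition at the concentration tested (going by the name of the read-out)), compound 2 gives 45.3%, the higher of the two numbers measured; compound 1 gives 31.3%, a reading lower by more than the usual scatter. Compound 3 `COc1cc(NC(=O)Nc2cc(Nc3cc(C)cc(F)c3)ncn2)cc(OC)c1` has not yet been measured. It differs from compound 2 in one place only: 3-fluoro-5-methylphenyl in place of 3,4-dimethylphenyl on a nitrogen on an aromatic ring. Among the compounds with values here, no measured pair differs in just this way, so nothing shows how large such a step is. The exchanged groups match in what is counted, one ring replacing another of the same size, so the step from compound 2 to compound 3 in this assay is expected to be small, most likely none beyond the scatter, with a slight lean downward. Compound 3 is therefore expected to give about 40%, between 25% and 55%. The expected step, a number 5.3 percentage points lower from compound 2 to compound 3 (within the scatter), stays within the scatter.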

Compound 3, a percentage reported as inhibition, at one concentration (the size of the read-out at that concentration, not a potency): 35.3%
Estimate against measurement, compound 3: 4.7 percentage points above; the range from low to high includes it.
By their numbers in this assay, from the lowest: compounds 1, 3 and 2 (each within the scatter of the next, the first and the last beyond it).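

In this assay, within the data shown here, replacing 3,4-dimethylphenyl with 3-fluoro-5-methylphenyl on a nitrogen on an aromatic ring gives a number 10 percentage points lower from compound 2 to compound 3 (within the scatter), the first direct reading of a change at this position. The two groups have the same count of heavy atoms and the same kind of ring, and this exchange of one phenyl pattern for the other, which brings in a fluorine, cannot be told apart from the usual variation between repeats. Nothing measured here explains the result.

On these data alone, because these two groups are so alike, it remains open whether a larger change at this nitrogen, such as a phenyl ring carrying an amine or a carboxylic acid, would shift the reading beyond the scatter. Compound 1 differs from both in more than one place, so it cannot settle this.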